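From (piperidin-1-yl)carbonyl to 2-(ethoxycarbonyl)ethenyl on the shared core

The source may hold more compounds than are shown below. What is called first, only, known or untested is meant among the compounds shown, and "the series" means these compounds.

In a functional assay (aorta) with Rattus norvegicus as the target (on this read-out lower numbers stand for an effect already at smaller amounts and higher numbers for an effect only at larger amounts of compound), compound 1 (`COc1ccc(-c2nc(CN(C)C)sc2-c2ccc(OC)cc2)cc1`) gives 8.4 uM and compound 2 (`COc1ccc(-c2nc(C(=O)N3CCCCC3)sc2-c2ccc(OC)cc2)cc1`) gives 11 uM on the shared core, so compound 2 stands within the scatter of compound 1. Compound 3 (`CCOC(=O)/C=C/c1nc(-c2ccc(OC)cc2)c(-c2ccc(OC)cc2)s1`), not yet measured, differs from compound 2 at one place: 2-(ethoxycarbonyl)ethenyl in place of (piperidin-1-yl)carbonyl on an aromatic carbon. Among the compounds with values here, one measured step bears on this place: a 1.3-fold higher number from compound 1 to compound 2 (0.12 log units; within the scatter) lies within the scatter, with (piperidin-1-yl)carbonyl in place of (dimethylamino)methyl. Within the data shown here, no measured compound carries 2-(ethoxycarbonyl)ethenyl, and that single step is thin support. In this assay no step beyond the scatter is therefore expected, in either direction. The expected step of a 1.1-fold lower number from compound 2 to compound 3 (0.04 log units; within the scatter) stays inside that scatter as estimated here. Compound 3 is estimated at 10 uM with a range from 3 uM to 35 uM for a single measurement.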

Compound 3, concentration for half-maximal effect: > 100 uM
Compound 3: only a limit was reported; the forecaster's own chance of this, stated with the estimate: 10%; middle value at least 10-fold (1.00 log units) away from the limit.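

In this assay, the two earlier groups on this aromatic carbon lay within the scatter of each other, which left the position looking undemanding, but 2-(ethoxycarbonyl)ethenyl shows that it does not accept every group, with an at least 9.0-fold higher number from compound 2 to compound 3 (0.95 log units; beyond the scatter) and an at least 11-fold higher number from compound 1 to compound 3 (1.07 log units; beyond the scatter). The reading for compound 3 is a limit and not a number: the limit of > 100 uM in this assay, at which 1 of the 3 values shown sits. Among these three compounds, the two groups that contain a nitrogen, (dimethylamino)methyl and (piperidin-1-yl)carbonyl, stay together, while the group without one stands apart, though a single compound carries that difference.

On these data alone, how large the two steps really are stays open. Also open, as far as these compounds go, is which part of the new group matters, and whether a carboxylic acid or an amine on the same chain, or a saturated ethyl ester chain, would return to the values of compound 1 and compound 2.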